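This account rests on a few compounds, and the source may have more. Where it says the series, first, only, none or still open, it means among the compounds named here.

Measured compounds in a functional assay on CCRF-CEM cells (Homo sapiens) for inhibition, read by MTT assay, with a stated time of 2 days, tested at 10 uM; on this read-out lower numbers stand for less inhibition and higher numbers for more inhibition at the one concentration tested (going by the name of the read-out):
Compound 1, `COc1ccccc1-c1cn(-c2ccc(O)c(C(=O)Nc3cccc(C(F)(F)F)c3)c2)nn1`, gives 65%.
Compound 2, `COc1cc(OC)cc(-c2cn(-c3ccc(O)c(C(=O)O)c3)nn2)c1`, gives 9%.
Compound 3, `COc1ccc(OC)c(-c2cn(-c3ccc(O)c(C(=O)OCCCc4ccccc4)c3)nn2)c1`, gives 5%.

Compound 3 holds the lowest number of the three. Its nearest neighbour is compound 2, whose value sits within the scatter of repeated measurements, so the two cannot be told apart; compound 1 stands far above both, beyond the scatter. Compound 4, `COc1cc(OC)cc(-c2cn(-c3ccc(O)c(C(=O)OCCCc4ccccc4)c3)nn2)c1`, has not yet been tested in this assay. It shares all its atoms with compound 3 and differs in one place: 3,5-dimethoxyphenyl in place of 2,5-dimethoxyphenyl on an aromatic carbon. Within the data shown here, no measured pair shows this single change on its own. The 3,5-dimethoxyphenyl group already appears in compound 2, which gives a low number, and compound 3 gives a low number with the 2,5-dimethoxyphenyl group, so nothing in the data points to a rise. The step is expected to stay within the scatter: a number 3 percentage points higher from compound 3 to compound 4 (within the scatter). Compound 4 is therefore estimated at 8%, with a range from 0% to 25%.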

Compound 4, a percentage reported as inhibition, at one concentration (the size of the read-out at that concentration, not a potency): 8%
Beside the measured number, compound 4's estimate shows no gap at the digits printed; measured number inside the range.
By their numbers in this assay, from the lowest: compounds 3, 4 and 2 (each within the scatter of the next); then compound 1.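

In this assay, putting 3,5-dimethoxyphenyl in place of 2,5-dimethoxyphenyl on the aromatic carbon of the five-membered ring gives a number 3 percentage points higher from compound 3 to compound 4 (within the scatter), so this change of methoxy pattern at this position does not separate the two compounds. Putting 3-phenylpropyl in place of hydrogen on the oxygen next to a carbonyl group gives a number 1 percentage points lower from compound 2 to compound 4 (within the scatter), so with 3,5-dimethoxyphenyl held constant, the carboxylic acid and its ester cannot be told apart either. Nothing available here explains either step.

Compound 1, at 65%, differs from compound 4 in more than one place, and the compounds shown do not say which of those differences goes with its number. Also open, as far as these compounds go, is whether an amine or a hydroxyl group on this aryl ring, or a shorter chain on that oxygen, would move the read-out.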